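Working notes: one added methyl on the side chain

A few compounds are considered here, and "the series" means these few. Any claim that something is new, unique, unknown or untested is made for them only; others in the source may bear on it.

Measured so far in a functional assay on HEL cells (Homo sapiens); a lower number here means that less compound is tolerated, a higher number that more compound is tolerated
compound 1 (`CCCCCCCCc1cc2cn(COCCO)c(O)nc-2n1`): 65000 nM
compound 2 (`CCCCCCCCC#Cc1cc2cn(COCCO)c(=O)nc2o1`): 42000 nM

Among the compounds with values here, compound 2 gives 42000 nM and lies within the scatter of compound 1, the only other measured compound. Compound 3 (`CCCCCCCCCC#Cc1cc2cn(COCCO)c(=O)nc2o1`) differs from compound 2 by methyl in place of hydrogen on a saturated chain carbon, eight bonds along the chain from a triple-bonded carbon. Within the data shown here, no measured pair isolates a change of this kind, so the data offer no direct guide to its size. In this assay no step beyond the scatter is expected, and two values support no direction. The expected change is a step of a 1.1-fold lower number from compound 2 to compound 3 (0.04 log units; within the scatter) that stays within the scatter. For compound 3 the estimated value is 38000 nM with an expected range from 14000 nM to 90000 nM for a single measurement.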

Compound 3, half-maximal cytotoxic concentration: > 50000 nM
Compound 3 ended at the assay's limit (the forecaster's own chance of this, stated with the estimate: 15%); at least 1.3-fold (0.11 log units) between middle value and limit.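

In this assay compound 3 gives > 50000 nM, which is a limit of the assay and not a number. Methyl in place of hydrogen on a saturated chain carbon, eight bonds along the chain from a triple-bonded carbon, now has its first measured pair, and it reads as an at least 1.1-fold higher number from compound 2 to compound 3 (0.07 log units; that floor lies within the scatter). Only this floor of the step is fixed, so the pair shows no change beyond the scatter but does not exclude one, and the limit recurs among the values of this series: the limit of > 50000 nM in this assay, at which 1 of the 3 values shown sits.

From the compounds shown here alone, the true size of the step stays open, as does its direction beyond that floor. Also open, going by these compounds, is whether a longer chain, or an amine or a carboxylic acid in place of the methyl, would give a value that can be read as a number in this assay.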